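The source may report more compounds than this note shows. Statements on the series, on what has been measured and on what is new or still open speak of the compounds shown alone.

Working notes on the series, measured in a functional assay on U-937 cells (Homo sapiens) for antiproliferative activity, read by MTT assay, with a stated time of 24 h; a higher number here means a weaker inhibitor, a lower number a stronger inhibitor:

- compound 1 `CCCCc1oc2ccccc2c1C(=O)c1ccc(OCC(N)=O)cc1` gives 42200 nM
- compound 2 `CCCCc1oc2ccccc2c1C(=O)c1ccc(OCC(=O)Nc2cccc(OC)c2)cc1` gives 24200 nM
- compound 3 `CCCCc1oc2ccccc2c1C(=O)c1ccc(OCCCC(=O)N2CCCCC2)cc1` gives 16600 nM

Compound 3 cannot be separated from compound 2, with a 1.5-fold lower number from compound 2 to compound 3 (0.16 log units; within the scatter). Only against compound 1 does it show a difference, with a 2.5-fold lower number from compound 1 to compound 3 (0.41 log units; beyond the scatter), and that step is modest. For the measured compounds named here, all three values sit close together, so the series so far shows a narrow spread.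

The next compound is compound 4 `CCCCc1oc2ccccc2c1C(=O)c1ccc(OCCCC(=O)NCc2ccccc2)cc1`, which differs from compound 3 as follows: benzylamino in place of piperidin-1-yl on a carbonyl carbon. In words, benzylamino stands in place of piperidin-1-yl on a carbonyl carbon. Going by the values given here, no measured compound carries the benzylamino group, so there is no direct precedent.

Among the compounds with values here, two measured steps bear on it indirectly. Placing a 3-methoxyphenyl group on the amide-type nitrogen gave a 1.7-fold lower number from compound 1 to compound 2 (0.24 log units; within the scatter). The change in the group on the saturated chain carbon, which also changes the amide, gave a 1.5-fold lower number from compound 2 to compound 3 (0.16 log units; within the scatter). Neither step leaves the scatter, so a shift beyond the scatter in this assay is not expected, and no direction is favoured with any confidence.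

The expected step is a 1.2-fold higher number from compound 3 to compound 4 (0.08 log units; within the scatter). For compound 4 the estimated value is 20000 nM, with an expected range from 10000 nM to 40000 nM.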

Compound 4, half-maximal inhibitory concentration: 15800 nM
Compound 4: middle estimate off by 1.3-fold (0.10 log units), on the high side, within the range that was stated.
By their numbers in this assay, from the lowest: compounds 4, 3, 2 and 1 (each within the scatter of the next, the first and the last beyond it).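

Exchanging piperidin-1-yl for benzylamino on a carbonyl carbon whose other neighbour is a saturated chain carbon gives a 1.1-fold lower number from compound 3 to compound 4 (0.02 log units; within the scatter) in this assay, so compound 3 and compound 4 cannot be told apart. This is the first pair shown in which only the group on this carbonyl carbon changes, and here a six-membered non-aromatic ring with no hydrogen-bond donor and a six-membered aromatic ring of carbon only, entering with 1 hydrogen-bond donor, read alike, which shows that this position accepts both groups without a shift beyond the scatter. No supporting data are available to explain why these two amides read alike.

The compounds shown leave open whether a methoxy group or a chlorine atom on the benzylamino ring, or morpholin-4-yl or 4-methylpiperazin-1-yl on the same carbonyl carbon, would move the number beyond the scatter. They also leave open whether a carboxylic acid in place of the amide, or a longer chain to the aromatic ring oxygen, would do so.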